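This account rests on a few compounds, and the source may have more. Where it says the series, first, only, none or still open, it means among the compounds named here.

In a functional assay on NCI-H460 cells (Homo sapiens) for inhibition, read by CCK-8 assay, with a stated time of 72 h, tested at 10 uM (on this read-out higher numbers stand for more inhibition of growth at the one concentration tested and lower numbers for less inhibition of growth), compound 1 (`CN(C)C(=O)c1cc2cnc(Nc3ccc(NC(=O)C4(C(=O)Nc5cccc(O)c5)CC4)cc3)nc2n1C1CCCC1`) gives 94.9% and compound 2 (`CN(C)C(=O)c1cc2cnc(Nc3ccc(NC(=O)C4(C(=O)Nc5ccc(Br)cc5)CC4)cc3)nc2n1C1CCCC1`) gives 96.4%, so compound 2 stands level with compound 1 within the scatter. The change to compound 3 (`CN(C)C(=O)c1cc2cnc(Nc3ccc(NC(=O)C4(C(=O)Nc5ccccc5)CC4)cc3)nc2n1C1CCCC1`) is hydrogen in place of bromo on an aromatic carbon and puts hydrogen in place of bromo on an aromatic carbon, turning 4-bromophenyl into phenyl. Among the measured compounds shown here, only one measured step bears on it: a number 1.5 percentage points higher from compound 1 to compound 2 (within the scatter), which swaps 3-hydroxyphenyl for 4-bromophenyl on the same amide-type nitrogen. For the measured compounds named here, no measured pair isolates the bromo alone, so this evidence is indirect. With that single small step as a guide, no change beyond the scatter is expected in this assay. The expected size is a number 4.4 percentage points lower from compound 2 to compound 3 (within the scatter) as an estimate. For compound 3 the estimated value is 92%, with an expected range from 80% to 100% in all.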

Compound 3, percent growth inhibition at one concentration: 95.9%
Compound 3: middle estimate off by 3.9 percentage points, on the low side; measured number inside the range.
By their numbers in this assay, from the lowest: compounds 1, 3 and 2 (each within the scatter of the next).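

Among the compounds shown here, the step of a number 0.5 percentage points lower from compound 2 to compound 3 (within the scatter) in this assay isolates the bromo for the first time, and removing it from its place on the six-membered aromatic ring leaves the number within the scatter. The step of a number 1 percentage points higher from compound 1 to compound 3 (within the scatter) shows the same for the hydroxy, so at the one concentration tested the unsubstituted phenyl stands level with both substituted rings and neither group is needed for this level of growth inhibition. Nothing available accounts for this flat result.

As far as these compounds go, it remains open whether a larger or differently built group on this ring, such as an amine, a carboxylic acid or a longer chain, would hold the number at this level. From the compounds shown here alone, it also remains open whether these three compounds would separate at lower concentrations.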